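A few compounds are considered here, and "the series" means these few. Any claim that something is new, unique, unknown or untested is made for them only; others in the source may bear on it.

In a functional assay on NUGC-3 cells (Homo sapiens) for cytotoxicity, read by sulforhodamine B assay, with a stated time of 72 h (a lower number here means a stronger inhibitor of growth, a higher number a weaker inhibitor of growth), compound 1 (`O=C(Nc1ccccc1O)C1CCc2ccccc2N1C(=O)c1ccccc1Cl`) gives 36800 nM. Compound 2 (`CCC(=O)N1c2ccccc2CCC1C(=O)Nc1ccccc1C(F)(F)F`) reads > 80000 nM, a value that is a limit of the assay and not a number. Compound 3 (`O=C(Nc1ccccc1C(F)(F)F)C1CCc2ccccc2N1C(=O)c1cccc(Cl)c1`) gives 754 nM, the lowest number of those measured and clearly lower than that of compound 1. Compound 4 (`O=C(Nc1ccccc1C(F)(F)F)C1CCc2ccccc2N1C(=O)c1ccccc1Cl`) differs from compound 3 at one place, with 2-chlorophenyl in place of 3-chlorophenyl on a carbonyl carbon. Going by the values given here, one measured step bears on this same place, an at least 100-fold lower number from compound 2 to compound 3 (2.02 log units; beyond the scatter). That large step shows that the group on this carbonyl carbon can matter, but it does not compare one chlorophenyl with another. Compound 1 carries the 2-chlorophenyl too and sits at 36800 nM, though it differs from compound 4 elsewhere, so it gives only a weak hint towards a higher number. The expected change is modest and upward, an estimated 2.7-fold higher number from compound 3 to compound 4 (0.42 log units; beyond the scatter). For compound 4 the estimated value is 2000 nM, with an expected range of 400 nM to 12000 nM.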

Compound 4, concentration for 50% growth inhibition: 2730 nM
The estimate for compound 4 lay 1.4-fold (0.14 log units) below the measured number; low and high end bracket the measured number.
By their numbers in this assay, from the lowest: compound 3; then compound 4; then compound 1. At a limit, above all of these: compound 2.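

In this assay, 2-chlorophenyl in place of 3-chlorophenyl on a carbonyl carbon gives a 3.6-fold higher number from compound 3 to compound 4 (0.56 log units; beyond the scatter), so moving the chlorine alone changes the number, but modestly beside the gain that 2-chlorophenyl in place of ethyl still retains, an at least 29-fold lower number from compound 2 to compound 4 (1.46 log units; beyond the scatter). Compound 2 stands at a limit of the assay and not at a number: the limit of > 80000 nM in this assay, at which 1 of the 4 values shown sits. Going by these compounds alone, with the 2-chlorophenyl held fixed, trifluoromethyl in place of hydroxy on an aromatic carbon gives a 13-fold lower number from compound 1 to compound 4 (1.13 log units; beyond the scatter), so the order of the chlorophenyl pair is seen only with trifluoromethyl present, and the second place counts for more than the chlorine shift.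

As far as these compounds go, whether the 3-chlorophenyl would also read lower with hydroxy in the other place remains open. So does how a phenyl without chlorine, or a bromophenyl, would read on this carbonyl carbon.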